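The source may hold more compounds than are shown below. What is called first, only, known or untested is meant among the compounds shown, and "the series" means these compounds.

Measured compounds:
compound 1 `CSc1cccc(C(=O)N2CCCC(C(=O)Nc3ccc(Cl)cc3)C2)c1`: 0%
compound 2 `O=C(Nc1cccc(OCCc2ccccn2)c1)C1CCCN(C(=O)c2cc(C(F)(F)F)cc(C(F)(F)F)c2)C1`: 5%
compound 3 `O=C(Nc1cccc(Oc2ccccc2)c1)C1CCCN(C(=O)c2cc(C(F)(F)F)cc(C(F)(F)F)c2)C1`: 1%

In an ADME assay on PC-3 cells (Homo sapiens) for cytotoxicity, read by WST assay, tested at 100 uM (on this read-out higher numbers stand for more inhibition at the one concentration tested (going by the name of the read-out) and lower numbers for less inhibition), compound 1 gives 0%. Compound 3 gives 1%, and compound 2 gives 5%; neither reading differs from that of compound 1 beyond the usual scatter, so the three compounds stand together at low inhibition. Within the data shown here, the one measured step between neighbours, a number 4 percentage points lower from compound 2 to compound 3 (within the scatter), is likewise within the scatter.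

Compound 4 `O=C(Nc1ccc(Cl)cc1)C1CCCN(C(=O)c2cccc(-c3cnco3)c2)C1` has not yet been measured. It differs from compound 1 by one change: 1,3-oxazol-5-yl in place of methylsulfanyl on an aromatic carbon. Among the measured compounds shown here, no measured step involves methylsulfanyl or 1,3-oxazol-5-yl, so nothing bears directly on this change. For the measured compounds named here, the only step available, a number 4 percentage points lower from compound 2 to compound 3 (within the scatter), exchanges a different group at a different place and stays within the scatter, and all three measured readings are low. Hence no step beyond the scatter is expected in this assay in either direction. Compound 4 is therefore estimated at 2%, with a range from 0% to 12%. The expected step of a number 2 percentage points higher from compound 1 to compound 4 (within the scatter) is thus a small one, within the scatter of this kind of measurement.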

Compound 4, a percentage reported as inhibition, at one concentration (the size of the read-out at that concentration, not a potency): 0%
Compound 4: the middle estimate sits 2 percentage points above what was measured, and the stated range covers the measured number.
By their numbers in this assay, from the lowest: compounds 1, 4, 3 and 2 (each within the scatter of the next).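

In this assay, putting 1,3-oxazol-5-yl in place of methylsulfanyl on an aromatic carbon, meta to a large group, gives no change at the digits printed from compound 1 to compound 4 (within the scatter). Among these compounds, this is the first measured change at this position, since the only earlier step concerned a group on an oxygen on an aromatic ring, and it shows that replacing a group of 2 heavy atoms and no ring with one of 5 heavy atoms and a five-membered aromatic ring does not bring out inhibition in these cells at the concentration tested. No measured information is available to explain this absence of change.

Among the compounds shown here, since the step joins two readings at the low end and covers only one pair of groups, it remains open whether any substituent at this aromatic carbon can raise the reading, for example an amine, a carboxylic acid or a longer chain in place of methylsulfanyl. Going by these compounds, it also remains open whether the same exchange would read alike in compounds carrying a different group on the amide nitrogen, such as the substituted phenyl rings of compound 2 and compound 3.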